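The source may report more compounds than this note shows. Statements on the series, on what has been measured and on what is new or still open speak of the compounds shown alone.

Compound 1 `CCCCC#Cc1cn(C/C=C\CN2C(=O)c3ccccc3C2=O)c(=O)[nH]c1=O` is the reference point here. For the measured compounds named here, in a functional assay on L1210 cells (Mus musculus) for antiproliferative activity, read by MTT assay, with a stated time of 2 days (a lower number here means a stronger inhibitor, a higher number a weaker inhibitor), compound 1 gives 109000 nM, the lowest of the two numbers so far. Its geometric isomer, compound 2 `CCCCC#Cc1cn(C/C=C/CN2C(=O)c3ccccc3C2=O)c(=O)[nH]c1=O`, gives 236000 nM in this assay, and the step of a 2.2-fold higher number from compound 1 to compound 2 (0.34 log units; beyond the scatter) rests on (the fact that compounds 1 and 2 differ only in the configuration as drawn). Compound 3 `CCCCc1ccc(C#Cc2cn(C/C=C\CN3C(=O)c4ccccc4C3=O)c(=O)[nH]c2=O)cc1` differs from compound 1 by 4-butylphenyl in place of butyl on a triple-bonded carbon. Going by the values given here, no measured step touches this change; the only known step concerns double-bond geometry, and it was modest. A modest step of a 1.1-fold lower number from compound 1 to compound 3 (0.04 log units; within the scatter) in this assay is therefore expected, with no firm direction. Compound 3 is estimated at 100000 nM, in the range 25000 nM to 400000 nM.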

Compound 3, half-maximal inhibitory concentration: 31000 nM
Beside the measured number, compound 3's estimate is 3.2-fold (0.51 log units) above it; the measured number falls inside the stated range.
By their numbers in this assay, from the lowest: compound 3; then compound 1; then compound 2.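

Putting 4-butylphenyl in place of butyl on a triple-bonded carbon brings a 3.5-fold lower number from compound 1 to compound 3 (0.55 log units; beyond the scatter) in this assay. For the compounds shown here, the earlier step concerned only double-bond geometry, so this is the first sign that the number also responds to the group at this position. No available evidence bears on why this change lowers the number.

The compounds shown leave open whether the six-membered aromatic ring or the butyl on it carries the step. An unsubstituted phenyl or a longer chain such as octyl would separate the two.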